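This account rests on a few compounds, and the source may have more. Where it says the series, first, only, none or still open, it means among the compounds named here.

Series notes. Compound 1 `COc1ccc2nc(N(Cc3cc(-c4ccc(OC(F)(F)F)cc4)no3)c3nc4ccc(F)cc4s3)sc2c1` gives 9940 nM in a functional assay on COLO 205 cells (Homo sapiens) for antiproliferative activity, read by MTT assay; a lower number here means a stronger inhibitor, a higher number a weaker inhibitor. Compound 2 `COc1ccc(-c2cc(CN(c3nc4ccc(F)cc4s3)c3nc4ccc(OC)cc4s3)on2)cc1` gives 11400 nM in this assay; the change methyl in place of trifluoromethyl on an oxygen on an aromatic ring made a step of a 1.1-fold higher number from compound 1 to compound 2 (0.06 log units; within the scatter). Compound 3 `FC(F)(F)Oc1ccc(-c2cc(CN(c3ncccn3)c3nc4ccccc4s3)on2)cc1` gives 5690 nM in this assay; the difference between its core and the core of compound 1 is not broken down here, and its value sits within the scatter of both compound 1 and compound 2. Compound 4 `COc1ccc(-c2cc(CN(c3ncccn3)c3nc4ccccc4s3)on2)cc1` carries the same change on the core of compound 3: methyl in place of trifluoromethyl on an oxygen on an aromatic ring, at the same place as in compound 2. For compound 4 the expected step is a 1.1-fold higher number from compound 3 to compound 4 (0.04 log units; within the scatter), which rests on the earlier 1.1-fold higher number from compound 1 to compound 2 (0.06 log units; within the scatter) seen on the other core. Compound 4 is therefore expected to give about 6300 nM in this assay, with a likely range from 2500 nM to 15000 nM.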

Compound 4, half-maximal inhibitory concentration: 5040 nM
Beside the measured number, compound 4's estimate is 1.3-fold (0.10 log units) above it; the measured number falls inside the stated range.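

On the core of compound 3, methyl in place of trifluoromethyl on the oxygen gives a 1.1-fold lower number from compound 3 to compound 4 (0.05 log units; within the scatter) in this assay. Set beside the same change on the other core, the two steps do not differ: the same change on two cores in this assay, a 1.1-fold higher number (0.06 log units; within the scatter) from compound 1 to compound 2 and a 1.1-fold lower number (0.05 log units; within the scatter) from compound 3 to compound 4, 1.3-fold (0.11 log units) apart, within the scatter of two such steps. The change therefore carries across these two cores without a step beyond the scatter on either one, but this shows neither a real effect of the change nor a direction for it, and two cores cannot speak for the rest of the series.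

The compounds shown leave open whether another group on this oxygen-bearing aromatic ring, such as an amine, a carboxylic acid or a longer alkoxy chain, would move the number beyond the scatter.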